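Removing the 3-methoxyphenyl group from compound 2

The source may report more compounds than this note shows. Statements on the series, on what has been measured and on what is new or still open speak of the compounds shown alone.

compound 1 `COc1ccc(CCCN2CCC(COCc3ccc(Cl)cc3)CC2)cc1` gives 500 nM
compound 2 `COc1cccc(CCCN2CCC(COC(c3ccccc3)c3ccccc3)CC2)c1` gives 1500 nM

In a functional assay on cells (T-cell line, Homo sapiens) for inhibition (a higher number here means a weaker inhibitor, a lower number a stronger inhibitor), compound 2 stands highest of the two at 1500 nM, and compound 1 stands at 500 nM. The gap between these two numbers lies beyond the scatter, with compound 2 on the weaker side. Compound 3 `CCCCCN1CCC(COC(c2ccccc2)c2ccccc2)CC1` is not yet measured. Compared with compound 2 it carries ethyl in place of 3-methoxyphenyl on a saturated chain carbon, three bonds along the chain from an amine nitrogen in a ring. Within the data shown here, no measured step covers this change. In this assay the expected change is a 2.0-fold higher number from compound 2 to compound 3 (0.30 log units; within the scatter) toward weaker inhibition. Compound 3 is estimated at 3000 nM (range 800 nM to 10000 nM).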

Compound 3, half-maximal inhibitory concentration: 10800 nM
The estimate for compound 3 lay 3.6-fold (0.56 log units) below the measured number; measured number outside the range, above it.
By their numbers in this assay, from the lowest: compound 1; then compound 2; then compound 3.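

Replacing the 3-methoxyphenyl group with ethyl on a saturated chain carbon, three bonds along the chain from an amine nitrogen in a ring, gives a 7.2-fold higher number from compound 2 to compound 3 (0.86 log units; beyond the scatter) in this assay and so shows that inhibition responds to a change at this position. The change removes an aromatic ring and a hydrogen-bond acceptor and weakens inhibition beyond the scatter. No available evidence accounts for this loss. The step changes the ring and the oxygen together, so their contributions remain unseparated. On these data alone, an unsubstituted phenyl, a pyridine ring or a longer alkyl chain at this position remains open.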